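The compounds below may be only part of what the source reports. "The series", "measured", "known", "first", "only" and "open" are said of these compounds alone.

Measured in a functional assay on MCF7 cells (Homo sapiens) for inhibition; a lower number here means a stronger inhibitor, a higher number a weaker inhibitor:
compound 1 `CC/C(=C(/c1ccc(/C=C/C(=O)O)cc1)c1cc2ccccc2[nH]1)c1ccccc1`, 108 nM
compound 2 `CC/C(=C(/c1ccc(/C=C/C(=O)O)cc1)c1cc2ccccc2[nH]1)c1ccccc1OC(F)(F)F`, 206 nM
compound 3 `CC/C(=C(/c1ccc(/C=C/C(=O)O)cc1)c1cc2ccccc2[nH]1)c1cccc(C(F)(F)F)c1`, 325 nM

Compound 3 gives the highest number of the three; it lies beyond the scatter from compound 1 (a 3.0-fold higher number from compound 1 to compound 3 (0.48 log units; beyond the scatter)) but within it from compound 2 (a 1.6-fold higher number from compound 2 to compound 3 (0.20 log units; within the scatter)). Compound 4 `CC/C(=C(/c1ccc(/C=C/C(=O)O)cc1)c1cc2ccccc2[nH]1)c1ccc(Cl)cc1` differs from compound 3 by 4-chlorophenyl in place of 3-(trifluoromethyl)phenyl on a double-bonded chain carbon bound to a double-bonded chain carbon and a saturated chain carbon. Within the data shown here, no measured step places chlorine on this ring. Among the measured compounds shown here, the only step swapping one substituted phenyl for another, a 1.6-fold higher number from compound 2 to compound 3 (0.20 log units; within the scatter), stayed within the scatter, as did a 1.9-fold higher number from compound 1 to compound 2 (0.28 log units; within the scatter); only a 3.0-fold higher number from compound 1 to compound 3 (0.48 log units; beyond the scatter) was modest but beyond. Compound 4 is therefore expected to show a step of a 1.5-fold lower number from compound 3 to compound 4 (0.19 log units; within the scatter), within the scatter. Compound 4 is estimated at 210 nM, range 80 nM to 550 nM.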

Compound 4, half-maximal inhibitory concentration: 343 nM
Beside the measured number, compound 4's estimate is 1.6-fold (0.21 log units) below it; the measured number falls inside the stated range.
By their numbers in this assay, from the lowest: compounds 1, 2, 3 and 4 (each within the scatter of the next, the first and the last beyond it).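

Replacing 3-(trifluoromethyl)phenyl with 4-chlorophenyl on the double-bonded chain carbon gives no resolved difference (a 1.1-fold higher number from compound 3 to compound 4 (0.02 log units; within the scatter)), and the same holds for replacing 2-(trifluoromethoxy)phenyl (a 1.7-fold higher number from compound 2 to compound 4 (0.22 log units; within the scatter)). Chloro in place of hydrogen is the second substitution on this phenyl to lie beyond the scatter from compound 1 (a 3.2-fold higher number from compound 1 to compound 4 (0.50 log units; beyond the scatter)), so compound 3 and compound 4 both separate from compound 1, while compound 2 goes against this by staying within the scatter of it. No available evidence accounts for these results.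

Going by these compounds, whether a methoxy or an amine on this phenyl would separate from compound 1 stays open.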